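The compounds below may be only part of what the source reports. "The series", "measured", "known", "first", "only" and "open" are said of these compounds alone.

Measured compounds in a functional assay on HeLa cells (Homo sapiens) for inhibition, read by sulforhodamine B assay, with a stated time of 48 h; on this read-out lower numbers stand for stronger inhibition of growth and higher numbers for weaker inhibition of growth:
compound 1 `Cc1ccn2c(CN3CCCCC3)c(-c3ccccc3)nc2n1` gives 1710 nM
compound 2 `c1ccc(-c2nc3ncccn3c2CN2CCCCC2)cc1` gives 2280 nM

Compound 1 holds the lowest of the two numbers shown; its nearest neighbour is compound 2, and the step of a 1.3-fold higher number from compound 1 to compound 2 (0.12 log units; within the scatter) is within the scatter, so the two compounds cannot be put in order. That step concerns hydrogen in place of methyl on an aromatic carbon and leaves the rest of the shared core untouched.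

Compound 3 `Cc1ccn2c(CN3CCCC3)c(-c3ccccc3)nc2n1` has not been measured. Its difference from compound 1: pyrrolidin-1-yl in place of piperidin-1-yl on a saturated chain carbon bound to an aromatic carbon. Going by the values given here, no measured step in this set touches the saturated chain carbon bound to an aromatic carbon or the ring attached there; the single available step, a 1.3-fold higher number from compound 1 to compound 2 (0.12 log units; within the scatter), concerns another position. Nothing in the data therefore anchors the direction of this change. The expected step of a 1.1-fold higher number from compound 1 to compound 3 (0.05 log units; within the scatter) is set at no change beyond the scatter, with a broadened range to reflect the missing anchor. Compound 3 is expected to give 1900 nM in this assay, estimated between 800 nM and 4500 nM.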

Compound 3, concentration for 50% growth inhibition: 180 nM
Compound 3: middle estimate off by 11-fold (1.02 log units), on the high side; measured number outside the range, below it.
By their numbers in this assay, from the lowest: compound 3; then compounds 1 and 2 (each within the scatter of the next).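

In this assay, going by these compounds alone, the saturated chain carbon bound to an aromatic carbon responds to substitution: pyrrolidin-1-yl in place of piperidin-1-yl gives a 9.5-fold lower number from compound 1 to compound 3 (0.98 log units; beyond the scatter), whereas the only earlier step, a 1.3-fold higher number from compound 1 to compound 2 (0.12 log units; within the scatter), concerned another position and stayed within the scatter. The change is small on the computed counts: the ring goes from six-membered to five-membered, while the hydrogen-bond donor and acceptor counts and the net charge stay the same. No measurement here accounts for the size of this step.

On these data alone, whether pyrrolidin-1-yl gives a step of similar size on the core of compound 2, which has hydrogen in place of the methyl, remains open. A single pair also cannot show whether ring size governs the response at this position, and other amines on the same saturated chain carbon, such as azetidin-1-yl, morpholin-4-yl or an open-chain dimethylamino group, would be needed to define how far it extends.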